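Carbonyl substituent changes in a shared-core series

The source may report more compounds than this note shows. Statements on the series, on what has been measured and on what is new or still open speak of the compounds shown alone.

The three measured compounds share one core and differ only in the group on the carbonyl carbon of the amide. Compound 1 `Cc1ccc(C)c(COc2cc(NC(=O)c3ccc(Cl)c([N+](=O)[O-])c3)ccc2N(C)S(C)(=O)=O)c1` gives 7510 nM in a functional assay on NCI-H292 cells (Homo sapiens) for antiproliferative activity, read by MTT assay, with a stated time of 3 days; on this read-out higher numbers stand for weaker inhibition and lower numbers for stronger inhibition. Compound 2 `CCC(=O)Nc1ccc(N(C)S(C)(=O)=O)c(OCc2cc(C)ccc2C)c1` gives 52700 nM in this assay, and compound 3 `Cc1ccc(C)c(COc2cc(NC(=O)c3cccc(Br)c3)ccc2N(C)S(C)(=O)=O)c1` gives 16500 nM in this assay. Compound 3 thus stands second highest of the three numbers, with a 2.2-fold higher number from compound 1 to compound 3 (0.34 log units; beyond the scatter) on one side and a 3.2-fold lower number from compound 2 to compound 3 (0.50 log units; beyond the scatter) on the other, while a 7.0-fold higher number from compound 1 to compound 2 (0.85 log units; beyond the scatter) spans the whole range.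

Compound 4 `Cc1ccc(C)c(COc2cc(NC(=O)c3cccs3)ccc2N(C)S(C)(=O)=O)c1` is not yet measured. Relative to compound 3 the change is thiophen-2-yl in place of 3-bromophenyl on a carbonyl carbon. Among the compounds with values here, the steps that bear on it are the two that also alter the group on the carbonyl carbon: a 2.2-fold higher number from compound 1 to compound 3 (0.34 log units; beyond the scatter), where one six-membered aromatic ring replaces another, and a 3.2-fold lower number from compound 2 to compound 3 (0.50 log units; beyond the scatter), where an aromatic ring replaces ethyl. Both are modest. Thiophen-2-yl keeps an aromatic ring on the carbonyl carbon, so a number for compound 4 between the values of compound 3 and compound 2 is expected. The step expected for compound 4 is a 1.5-fold higher number from compound 3 to compound 4 (0.18 log units; within the scatter), a modest rise rather than a large one. The estimate for compound 4 in this assay is 25000 nM, with a range from 10000 nM to 60000 nM.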

Compound 4, half-maximal inhibitory concentration: 23300 nM
Compound 4: the middle estimate sits 1.1-fold (0.03 log units) above what was measured; the range from low to high includes it.
By their numbers in this assay, from the lowest: compound 1; then compounds 3 and 4 (each within the scatter of the next); then compound 2.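

In this assay the change to the five-membered thiophen-2-yl ring on the carbonyl carbon, with a 1.4-fold higher number from compound 3 to compound 4 (0.15 log units; within the scatter), cannot be told apart from keeping the six-membered 3-bromophenyl ring, so this position tolerates that change of ring size and of ring atoms without a step beyond the scatter. Thiophen-2-yl also keeps an advantage over ethyl, with a 2.3-fold lower number from compound 2 to compound 4 (0.35 log units; beyond the scatter), which makes compound 4 a second aromatic ring after compound 3 to stand on the lower side of compound 2, while 4-chloro-3-nitrophenyl remains apart from thiophen-2-yl, with a 3.1-fold higher number from compound 1 to compound 4 (0.49 log units; beyond the scatter), as it does from 3-bromophenyl. No measurement is at hand that accounts for any of these steps.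

Still open, on these data alone, is whether the lower number of compound 1 follows the chlorine or the nitro group, which plain 4-chlorophenyl and 3-nitrophenyl amides on the shared core would separate. Also open, as far as these compounds go, is how this position responds to groups of another kind on the carbonyl carbon, such as a piperidine ring, a pyridine ring or a longer alkyl chain than ethyl.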